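This account rests on a few compounds, and the source may have more. Where it says the series, first, only, none or still open, it means among the compounds named here.

Compound 1 `C[C@H](NC(=O)Cn1nnc2ccccc2c1=O)c1ccc(OC(F)F)cc1` and compound 3 `COc1cccc2nnn(CC(=O)N[C@@H](C)c3ccc(OC(F)F)cc3)c(=O)c12` share one core and differ only by methoxy in place of hydrogen on an aromatic carbon. In an ADME assay on microsomes from liver (Homo sapiens) for metabolic stability (on this read-out higher numbers stand for fast clearance and lower numbers for slow clearance), compound 1 gives only a limit of the assay, < 9.9 mL/min/kg. In this assay compound 3 likewise gives only a limit, < 9.9 mL/min/kg. The step that the two limits leave unreadable from compound 1 to compound 3 therefore cannot be read. Compound 2 `C[C@H](NC(=O)Cn1nnc2ccccc2c1=O)c1ccc(OC(F)(F)F)cc1F` carries a different core from compound 1; how the two cores differ is not broken down here. In this assay compound 2 gives only a limit, < 9.9 mL/min/kg. Compound 4 `COc1cccc2nnn(CC(=O)N[C@@H](C)c3ccc(OC(F)(F)F)cc3F)c(=O)c12` arises from compound 2 by the same change, (methoxy in place of hydrogen on an aromatic carbon). Among the measured compounds shown here, because every value so far sits at the limit of < 9.9 mL/min/kg in this assay, at which 3 of the 3 values shown sit, the step expected is a step that the limit leaves unreadable from compound 2 to compound 4 and is itself only an expectation. Compound 4 is accordingly expected to give 7 mL/min/kg, between 3 mL/min/kg and 14 mL/min/kg, most probably reported again as a limit.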

Compound 4, clearance: 41 mL/min/kg
Compound 4: middle estimate off by 5.9-fold (0.77 log units), on the low side, outside the stated range (above it).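

On the core of compound 2, methoxy in place of hydrogen on an aromatic carbon gives an at least 4.1-fold higher number from compound 2 to compound 4 (0.61 log units; beyond the scatter) in this assay, so here the change moves the compound towards faster clearance. On the core of compound 1, the same change leaves compound 3 at a limit of the assay, yet this does not show that the change behaves differently on the two cores. The step there cannot be read, so the two steps cannot be compared, because compound 1 and compound 3 both stand at a limit: the limit of < 9.9 mL/min/kg in this assay, at which 3 of the 4 values shown sit.

From the compounds shown here alone, what an amine or a carboxylic acid on that aromatic carbon would give in this assay stays open. Going by these compounds, it also stays open which part of the difference between the two cores goes with the higher number for compound 4.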